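Furan-to-thiophene swap across two ring-size variants

The source may report more compounds than this note shows. Statements on the series, on what has been measured and on what is new or still open speak of the compounds shown alone.

Measured so far in a functional assay on the whole organism (plasma, strain Sprague-Dawley) with Rattus norvegicus as the target, with a stated time of 2 h, at a dose of 25 mg/kg by the oral route; a lower number here means a weaker effect, a higher number a stronger effect of the compound at the dose given:
compound 1, `c1ccc(C(/N=C2\CCCCN2)c2ccco2)cc1`, gives 10%
compound 2, `c1ccc(C(/N=C2\CCCCCCN2)c2ccco2)cc1`, gives 29%
compound 3, `c1ccc(C(/N=C2\CCCCN2)c2cccs2)cc1`, gives 31%

Compound 3 differs from compound 1 by thiophen-2-yl in place of furan-2-yl on a saturated chain carbon bound to an aromatic carbon and a double-bonded nitrogen; the step of a number 21 percentage points higher from compound 1 to compound 3 (beyond the scatter). The difference between the cores of compound 1 and compound 2 is not broken down here; their two values show compound 2 higher. Compound 4, `c1ccc(C(/N=C2\CCCCCCN2)c2cccs2)cc1`, has not been measured; it differs from compound 2 by thiophen-2-yl in place of furan-2-yl on a saturated chain carbon bound to an aromatic carbon and a double-bonded nitrogen, the same change made on the core of compound 2. Within the data shown here, the step of a number 16 percentage points higher from compound 2 to compound 4 (beyond the scatter) is expected to be about as large as the earlier one, because a number 21 percentage points higher from compound 1 to compound 3 (beyond the scatter) is the only guide here. Compound 4 is therefore expected to give 45% in this assay, between 25% and 65%.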

Compound 4, a percentage reported as inhibition, in the whole organism at one dose (the size of the read-out at that dose, not a potency): 37%
Estimate against measurement, compound 4: 8 percentage points above, and the stated range covers the measured number.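

In this assay, thiophen-2-yl in place of furan-2-yl now gives a number 8 percentage points higher from compound 2 to compound 4 (within the scatter), a step that on its own cannot be told from scatter. Set beside the earlier step on the other core, it does not differ: the same change on two cores in this assay, a number 21 percentage points higher (beyond the scatter) from compound 1 to compound 3 and a number 8 percentage points higher (within the scatter) from compound 2 to compound 4, 13 percentage points apart, within the scatter of two such steps. This is compatible with the change carrying over between the two cores, but two pairs do not prove that it does, nor do they fix the size of the step on either core.

The compounds shown leave open whether a pyridin-2-yl or thiazol-2-yl group at the same place would follow the same course. Also open, going by these compounds, is whether the comparison would hold at other doses or sampling times.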